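The source may report more compounds than this note shows. Statements on the series, on what has been measured and on what is new or still open speak of the compounds shown alone.

Compound 2 `C/C(=N\Nc1nc2ccccc2nc1Cc1ccccc1)c1ccc(C)cc1` was tested in an assay on isolated protein for inhibition of Amine oxidase [flavin-containing] B (Homo sapiens), read by spectrophotometry (on this read-out higher numbers stand for weaker inhibition and lower numbers for stronger inhibition), where compound 2 gives 740000 nM. For the measured compounds named here, its only measured neighbour is compound 1 `C/C(=N\Nc1nc2ccccc2nc1Cc1ccccc1)c1ccccc1`, which in this assay gives 980000 nM; the step of a 1.3-fold lower number from compound 1 to compound 2 (0.12 log units; within the scatter) is a methyl in place of hydrogen on an aromatic carbon, so the two values are within the scatter of each other and neither compound can be ranked above the other. Compound 3 `C/C(=N\Nc1nc2ccccc2nc1Cc1ccccc1)c1ccc(N)cc1` has not yet been measured. It differs from compound 2 by amino in place of methyl on an aromatic carbon. Going by the values given here, no measured step exchanges one group for another at this aromatic carbon, so only the step from compound 1 to compound 2 bears on it, and that one is within the scatter. On this basis the step of a 1.1-fold lower number from compound 2 to compound 3 (0.02 log units; within the scatter) is expected to stay within the scatter. Compound 3 is therefore estimated at 700000 nM in this assay, with a range from 250000 nM to 2000000 nM.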

Compound 3, half-maximal inhibitory concentration: 860000 nM
Compound 3: the middle estimate sits 1.2-fold (0.09 log units) below what was measured, and the stated range covers the measured number.
By their numbers in this assay, from the lowest: compounds 2, 3 and 1 (each within the scatter of the next).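

In this assay, the step of a 1.2-fold higher number from compound 2 to compound 3 (0.07 log units; within the scatter) and the step of a 1.1-fold lower number from compound 1 to compound 3 (0.06 log units; within the scatter) place amino beside methyl and hydrogen at this aromatic carbon, and all three compounds lie within the scatter of one another. For the compounds shown here, this is the first change at this position that brings in a hydrogen-bond donor and a hydrogen-bond acceptor, and the read-out does not separate it from either methyl or hydrogen. Nothing available here bears on why the three values sit together.

On these data alone, it remains open whether a larger or differently built group at this place, such as a carboxylic acid, a nitrile or a longer chain, would give a step beyond the scatter. Equally open, as far as these compounds go, is whether a change elsewhere on the shared core would do so.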